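The compounds below may be only part of what the source reports. "The series", "measured", "known", "first", "only" and "open" are said of these compounds alone.

Measured so far:
compound 1 `CCC(=O)Nc1cccc(S(=O)(=O)Oc2ccccc2C(C)C)c1`: 14000 nM
compound 2 `CC(=O)Nc1ccc(S(=O)(=O)Oc2ccccc2C(C)C)cc1`: 16000 nM

In a functional assay on MCF7 cells (Homo sapiens) for antiproliferative activity, read by sulforhodamine B assay, with a stated time of 48 h (on this read-out higher numbers stand for weaker inhibition and lower numbers for stronger inhibition), compound 2 gives 16000 nM. Compound 1 gives 14000 nM. Compound 2 has the larger of the two numbers, but the gap to compound 1 is within the scatter, so the two values show no real difference. Compound 3 `CC(C)C(=O)Nc1ccc(S(=O)(=O)Oc2ccccc2C(C)C)cc1` carries isopropyl in place of methyl on a carbonyl carbon, isopropyl in place of methyl on a carbonyl carbon. Among the compounds with values here, no step between measured compounds covers this change. The step expected here is a 1.1-fold lower number from compound 2 to compound 3 (0.03 log units; within the scatter), none beyond the scatter. For compound 3 the estimate is 15000 nM, expected to fall between 7000 nM and 35000 nM.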

Compound 3, half-maximal inhibitory concentration: 8600 nM
For compound 3 the middle estimate is 1.7-fold (0.24 log units) above the measured one; low and high end bracket the measured number.
By their numbers in this assay, from the lowest: compounds 3, 1 and 2 (each within the scatter of the next).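

In this assay, within the data shown here, isopropyl in place of methyl on a carbonyl carbon gives a 1.9-fold lower number from compound 2 to compound 3 (0.27 log units; within the scatter) as the first readable step at this position. This single pair therefore shows no real difference between acetamido and (isopropylcarbonyl)amino, and it sets no trend for this position. Nothing at hand speaks to the origin of this step.

Going by these compounds, whether a longer chain, a phenyl ring or an amine on the carbonyl carbon would give a step beyond the scatter remains open. Compound 1 differs from compound 2 and from compound 3 in more than one place, so neither pair isolates a single change.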